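A Phenyl for a Difluorophenyl: Expected Inhibition

The source may report more compounds than this note shows. Statements on the series, on what has been measured and on what is new or still open speak of the compounds shown alone.

Three compounds have been measured in an assay on CHO cells for displacement of a labelled ligand from adenosine receptor A3 (Homo sapiens), read by scintillation counting, tested at 10 uM; a lower number here means less inhibition, a higher number more inhibition at the concentration tested (going by the name of the read-out):

compound 1 `COc1ccc(-c2sc(N)c(C(=O)c3ccc(Cl)cc3)c2C)cc1`: 1%
compound 2 `CC(C)(C)Cc1c(-c2cc(F)ccc2F)sc(N)c1C(=O)c1ccc(Cl)cc1`: 1%
compound 3 `CC(C)(C)Cc1c(Br)sc(N)c1C(=O)c1cccc(Cl)c1`: 1%

All three share a five-membered aromatic ring with one sulfur, carrying an amino group and a chlorophenyl carbonyl. In this assay compound 2 gives 1%, level with compound 1 and compound 3 at the digits shown; the gaps to both lie within the usual scatter of repeated measurements, so nothing separates the three.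

Compound 4 `CC(C)(C)Cc1c(-c2ccccc2)sc(N)c1C(=O)c1ccc(Cl)cc1` has not yet been measured. It differs from compound 2 in one place: phenyl in place of 2,5-difluorophenyl on an aromatic carbon

Going by the values given here, no step between two measured compounds is known here, so the size of this change can only be judged from the three values at hand, which all sit at the same low level. The expectation is that compound 4 stays there, with no step beyond the scatter in either direction. The expected step is a number 1 percentage points higher from compound 2 to compound 4 (within the scatter). Compound 4 is expected to give 2% in this assay, with a range from -8% to 12%.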

Compound 4, a percentage reported as inhibition, at one concentration (the size of the read-out at that concentration, not a potency): 1%
Estimate against measurement, compound 4: 1 percentage points above; the range from low to high includes it.
By their numbers in this assay, from the lowest: compounds 1, 2, 3 and 4 (each within the scatter of the next).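

Swapping the 2,5-difluorophenyl group for phenyl, next to the ring sulfur, gives the first direct one-place comparison among these compounds: this assay shows no change at the digits printed from compound 2 to compound 4 (within the scatter). At this position the two fluorines therefore leave no visible mark on the read-out, although both compounds sit so low, with compound 4 at 1%, that the comparison says little about how the groups would differ at a higher level of inhibition. No measurement at hand offers an explanation for this result.

Still open, from the compounds shown here alone, is whether any group at this position can raise the inhibition, for instance an amine, a carboxylic acid or a longer chain in place of the phenyl. Going by these compounds, the same swap also remains unknown on a core with a different group in place of the neopentyl.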